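The source may hold more compounds than are shown below. What is called first, only, known or untested is meant among the compounds shown, and "the series" means these compounds.

Measured so far:
- compound 1 `COc1cc(N(Cc2ccc(Cl)cc2)C(=O)CSC(=S)N2CCN(C(=O)OC(C)(C)C)CC2)cc(OC)c1OC`: 11900 nM
- compound 2 `COc1ccc(CN(C(=O)CSC(=S)N2CCN(C(=O)OC(C)(C)C)CC2)c2cc(OC)c(OC)c(OC)c2)cc1Br`: 1850 nM
- compound 3 `COc1ccc(CN(C(=O)CSC(=S)N2CCN(C(=O)OC(C)(C)C)CC2)c2cc(OC)c(OC)c(OC)c2)cc1C`: > 20000 nM, a limit of the assay

In a functional assay on KYSE-450 cells (Homo sapiens) for inhibition, read by CCK-8 assay, with a stated time of 48 h (a lower number here means a stronger inhibitor, a higher number a weaker inhibitor), compound 3 stands at > 20000 nM, which is a limit and not a number. Compound 4 `COc1ccc(CN(C(=O)CSC(=S)N2CCN(C(=O)OC(C)(C)C)CC2)c2cc(OC)c(OC)c(OC)c2)cc1N=[N+]=[N-]` has azido in place of methyl on an aromatic carbon, ortho to a methoxy group: azido in place of methyl on an aromatic carbon. The measured step that bears most directly on this is the large at least 10-fold higher number from compound 2 to compound 3 (1.03 log units; beyond the scatter), where methyl replaces bromo at the same place. Two further steps change the whole benzyl-side ring: the modest 6.4-fold lower number from compound 1 to compound 2 (0.81 log units; beyond the scatter) and an at least 1.6-fold higher number from compound 1 to compound 3 (0.22 log units; that floor lies within the scatter), whose floor lies within the scatter. Azido itself is untested here, so a sizeable move towards a lower number is expected, but with wide uncertainty. The estimated step is an at least 4.0-fold lower number from compound 3 to compound 4 (0.60 log units; beyond the scatter). For compound 4 the expected value is 5000 nM, within an estimated range of 1500 nM to 20000 nM.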

Compound 4, half-maximal inhibitory concentration: 840 nM
Compound 4: middle estimate off by 6.0-fold (0.77 log units), on the high side; measured number outside the range, below it.
By their numbers in this assay, from the lowest: compound 4; then compound 2; then compound 1. At a limit, above all of these: compound 3.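

In this assay, azido on this aromatic carbon, ortho to a methoxy group, outdoes bromo, the best group seen there until now, with a 2.2-fold lower number from compound 2 to compound 4 (0.34 log units; beyond the scatter) beyond the scatter. The gain over methyl, an at least 23-fold lower number from compound 3 to compound 4 (1.37 log units; beyond the scatter) and over the 4-chlorophenyl ring, a 14-fold lower number from compound 1 to compound 4 (1.15 log units; beyond the scatter) places this compound lowest of the four. Compound 3 gives a limit and not a number: the limit of > 20000 nM in this assay, at which 1 of the 4 values shown sits.

From the compounds shown here alone, whether an amine, a nitrile or a methoxy group on this carbon would lower the number further stays open. The compounds shown also cannot tell why azido and bromo outperform methyl here.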